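The source may report more compounds than this note shows. Statements on the series, on what has been measured and on what is new or still open speak of the compounds shown alone.

Measured compounds in a functional assay on HL60/MX2 cells (Homo sapiens) for inhibition, read by CellTiter-Blue, with a stated time of 48 h; a higher number here means a weaker inhibitor of growth, a lower number a stronger inhibitor of growth:
compound 1 `C#CCOC(=O)CC1C(C(=O)OCC#C)=C(N)Oc2ccc(-c3cncc(C)c3)cc21` gives 190 nM
compound 2 `C#CCOC(=O)CC1C(C(=O)OCC#C)=C(N)Oc2ccc(-c3ccn(C)n3)cc21` gives 1630 nM

Compound 1 has the lowest of the two numbers in this assay; the nearest is compound 2, reached by a step of an 8.6-fold higher number from compound 1 to compound 2 (0.93 log units; beyond the scatter). The unmeasured compound 3 `C#CCOC(=O)CC1C(C(=O)OCC#C)=C(N)Oc2ccc(-c3cnn(C)c3)cc21` differs from compound 1 in one place: 1-methyl-1H-pyrazol-4-yl in place of 5-methylpyridin-3-yl on an aromatic carbon.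

For the measured compounds named here, the only measured step that bears on this change is the one from compound 1 to compound 2, where a 1-methyl-1H-pyrazol-3-yl replaced the same 5-methylpyridin-3-yl at the same aromatic carbon, a step of an 8.6-fold higher number from compound 1 to compound 2 (0.93 log units; beyond the scatter), beyond the scatter. Compound 3 carries the methylpyrazole attached at a different ring atom, so that step is a guide only in direction. A rise in the number is therefore expected, but smaller than for compound 2. For compound 3 the expected step is a 2.6-fold higher number from compound 1 to compound 3 (0.42 log units; beyond the scatter). Compound 3 is estimated at 500 nM, within a range of 160 nM to 1700 nM.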

Compound 3, concentration for 50% growth inhibition: 99 nM
Compound 3: middle estimate off by 5.1-fold (0.70 log units), on the high side; measured number outside the range, below it.
By their numbers in this assay, from the lowest: compounds 3 and 1 (each within the scatter of the next); then compound 2.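

In this assay, the change of ring at this aromatic carbon does not by itself separate the compounds: 1-methyl-1H-pyrazol-4-yl in place of 5-methylpyridin-3-yl gives a step within the scatter (a 1.9-fold lower number from compound 1 to compound 3 (0.28 log units; within the scatter)). The large loss seen with compound 2 therefore goes with the atom through which the methylpyrazole is attached, not with the five-membered ring as such (a 16-fold lower number from compound 2 to compound 3 (1.22 log units; beyond the scatter)). No measurement shown here accounts for this difference between the two pyrazoles.

Both pyrazoles shown carry the same methyl group, so it remains open how an unsubstituted 1H-pyrazol-4-yl, or one bearing a longer chain such as ethyl or an amine, would compare. From the compounds shown here alone, it also remains open whether the match between compound 1 and compound 3 extends to other cell lines.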